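This account rests on a few compounds, and the source may have more. Where it says the series, first, only, none or still open, it means among the compounds named here.

Measured so far in an in vivo ADME assay on the whole organism (plasma, strain Sprague-Dawley) for pharmacokinetics, with Rattus norvegicus as the target, read by LC-MS, at a dose of 10 mg/kg by the oral route; on this read-out lower numbers stand for lower oral bioavailability and higher numbers for higher oral bioavailability:
Compound 1, `CC1(C)CC(Oc2ccc(C(=O)Nc3ccc(NC(=O)Nc4cc(C(C)(C)C)on4)cc3)nc2)CC(C)(C)N1`, gives 8%
Compound 2, `CC(C)(C)c1cc(NC(=O)Nc2ccc(NC(=O)c3cc(OC4CCNCC4)ccn3)cc2)no1`, gives 3%
Compound 3, `Cc1ccnc(C(=O)Nc2ccc(NC(=O)Nc3cc(C(C)(C)C)on3)cc2)c1`, gives 4%

All three share one core and all three numbers are low. Compound 1 stands highest of the three, but its gap to compound 3 and its gap to compound 2 both lie within the scatter, so no real order among them can be read from these numbers. Among the compounds with values here, only one step between compounds differing in a single place is known: a number 1 percentage points higher from compound 2 to compound 3 (within the scatter).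

Compound 4, `CCN1CCC(Cc2ccc(C(=O)Nc3ccc(NC(=O)Nc4cc(C(C)(C)C)on4)cc3)nc2)CC1`, has not yet been measured. It differs from compound 1 in one place: (1-ethylpiperidin-4-yl)methyl in place of (2,2,6,6-tetramethylpiperidin-4-yl)oxy on an aromatic carbon. Within the data shown here, the step from compound 2 to compound 3, which also removed a (piperidin-4-yl)oxy group from the core, is the only measured step that bears on this change, and it moved nothing beyond the scatter. With nothing else to go on, compound 4 is expected to stay in the same low region as compound 1, with an expected step of a number 2 percentage points higher from compound 1 to compound 4 (within the scatter), which is none beyond the scatter. Compound 4 is therefore estimated at 10%, in a range from 2% to 25%.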

Compound 4, oral bioavailability: 12%
Estimate against measurement, compound 4: 2 percentage points below; low and high end bracket the measured number.
By their numbers in this assay, from the lowest: compounds 2, 3, 1 and 4 (each within the scatter of the next).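

In this assay, exchanging (2,2,6,6-tetramethylpiperidin-4-yl)oxy for (1-ethylpiperidin-4-yl)methyl gives a number 4 percentage points higher from compound 1 to compound 4 (within the scatter), the first step shown at this position, an aromatic carbon two atoms from the ring nitrogen. Both groups hold a six-membered non-aromatic ring, and the leaving group has 1 hydrogen-bond donor where the entering group has 0 hydrogen-bond donors, yet the number does not move beyond the scatter, so this position takes the exchange without a clear shift in oral bioavailability. No supporting measurement is available to explain this result.

From the compounds shown here alone, the exchange alters the oxygen link, the ring's methyl groups and the ethyl group together, so the share of each stays open. Going by these compounds, whether a carboxylic acid or a longer chain at this position would move the number beyond the scatter also stays open.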